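Adding a Chloro Group to Compound 2

The compounds below may be only part of what the source reports. "The series", "measured", "known", "first", "only" and "open" are said of these compounds alone.

In a functional assay on HO8910 cells (Homo sapiens) for inhibition, read by MTT assay, with a stated time of 24 h, tested at 1 ug/mL (a lower number here means less inhibition of growth, a higher number more inhibition of growth at the concentration tested), compound 1 (`O=C(CCCCC(S)CCS)Nc1cccc(Cl)c1`) is reported as "not active" (no number reported), with no number given. Compound 2 (`CC(=O)SCCC(CCCCC(=O)Nc1ccccc1)SC(C)=O`) gives 10.6%. Among the compounds with values here, this is the only number available, so compound 2 cannot yet be ranked against any measured neighbour. Compound 3 (`CC(=O)SCCC(CCCCC(=O)Nc1ccc(Cl)cc1)SC(C)=O`) has not yet been measured. It differs from compound 2 by a single change, chloro in place of hydrogen on an aromatic carbon, para to a large group: chloro in place of hydrogen on an aromatic carbon. Within the data shown here, no measured pair shows what such a change does, so the expectation rests on thin evidence. A small rise is expected in this assay, probably not beyond the usual scatter, and the estimated move is a number 2.4 percentage points higher from compound 2 to compound 3 (within the scatter). The expected value for compound 3 is 13%, with an estimated range from 2% to 30%.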

Compound 3, percent growth inhibition at one concentration: 0.35%
Compound 3: the middle estimate sits 12.7 percentage points above what was measured, outside the stated range (below it).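

In this assay, placing chloro in place of hydrogen on the aromatic carbon para to a large group gives a number 10.3 percentage points lower from compound 2 to compound 3 (beyond the scatter). Within the data shown here, this is the first step that can be read, and it shows that this position is not indifferent to the change: going from phenyl to 4-chlorophenyl lowers the growth inhibition, already small in the unsubstituted anilide, instead of raising it. Nothing available accounts for this drop.

The compounds shown leave open whether the loss belongs to chloro itself or would follow any replacement of that hydrogen, such as fluoro, a methyl group or an amine. They also leave open whether a carboxylic acid on the same carbon would preserve the modest inhibition seen with compound 2.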